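Swapping the Carbamate Aryl Group in a Pancreatic Cell Assay

The source may hold more compounds than are shown below. What is called first, only, known or untested is meant among the compounds shown, and "the series" means these compounds.

Among the measured compounds shown here, compound 2 `COc1cccc(NC(=O)Oc2cc(=O)n(CCCO)c3c2CC(C/C=C(\C)CCC=C(C)C)C(C)(C)C3)c1` holds the higher of the two numbers so far in a functional assay on PANC-1 cells (Homo sapiens) for inhibition, read by MTT assay, with a stated time of 24 h, tested at 10 uM (a lower number here means less inhibition, a higher number more inhibition at the concentration tested (going by the name of the read-out)), where compound 2 gives 11.3%. For the measured compounds named here, its nearest neighbour is compound 1 `COc1cccc(NC(=O)Oc2cc(=O)n(CCCO)c3c2CC(CC=C(C)C)C(C)(C)C3)c1`, which in this assay gives 0%; the one measured step, a number 11.3 percentage points higher from compound 1 to compound 2 (beyond the scatter), concerns the side chain on the shared core and not the carbamate. Compound 3 `CC(C)=CCC/C(C)=C/CC1Cc2c(OC(=O)Nc3ccc(Cl)cc3)cc(=O)n(CCCO)c2CC1(C)C` differs from compound 2 at the other end of the molecule: 4-chlorophenyl in place of 3-methoxyphenyl on an amide-type nitrogen. Going by the values given here, no measured pair shows what an exchange of the aryl group on the amide-type nitrogen does, so the step from compound 1 to compound 2 offers no guide for it. With nothing to point either way, the step is expected to be a number 0.3 percentage points lower from compound 2 to compound 3 (within the scatter), within the usual scatter. Compound 3 is therefore estimated to give 11% in this assay, with a range from 0% to 25%.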

Compound 3, a percentage reported as inhibition, at one concentration (the size of the read-out at that concentration, not a potency): 4.3%
The estimate for compound 3 lay 6.7 percentage points above the measured number, and the stated range covers the measured number.
By their numbers in this assay, from the lowest: compounds 1, 3 and 2 (each within the scatter of the next, the first and the last beyond it).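

In this assay, among the compounds shown here, the first reading at this position comes from 4-chlorophenyl in place of 3-methoxyphenyl on the amide-type nitrogen, which gives a number 7 percentage points lower from compound 2 to compound 3 (within the scatter). The earlier step concerned the side chain and lay beyond the scatter, whereas this exchange of one aryl group for another stays within it, so this pair shows no measurable effect of the change at the concentration tested. Nothing measured on these compounds offers an explanation for this result.

On these data alone, it remains open whether an aryl group carrying an amine or a carboxylic acid on the amide-type nitrogen would shift the number beyond the scatter. Also open, as far as these compounds go, is whether 4-chlorophenyl would behave the same way with the side chain of compound 1, which on its own gives 0%.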